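This account rests on a few compounds, and the source may have more. Where it says the series, first, only, none or still open, it means among the compounds named here.

Three compounds have been measured in an in vitro functional assay on HEK285-7 cells for antagonist activity at prostaglandin D2 receptor 2 (Homo sapiens), read by BRET and beta-arrestin recruitment; on this read-out higher numbers stand for weaker inhibition and lower numbers for stronger inhibition:
Compound 1, `O=C(O)Cc1sc(C(c2ccccc2)c2ccccc2)nc1-c1ccccc1`, gives 370 nM.
Compound 2, `Nc1nc(-c2ccc(Cl)cc2)c(CC(=O)O)s1`, reaches only the limit of the assay, > 100000 nM.
Compound 3, `O=C(O)Cc1sc(C(c2ccc(F)cc2)c2ccc(F)cc2)nc1-c1ccnc(N2CCCC2)c1`, likewise reaches only the limit of the assay, > 100000 nM.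

Compound 3 therefore stands at the weak end of the numbers shown, sitting at the limit of > 100000 nM in this assay, at which 2 of the 3 values shown sit, and no numeric value is known for it. Compound 4, `O=C(O)Cc1sc(C(c2ccc(F)cc2)c2ccc(F)cc2)nc1-c1ccnc(Cl)c1`, differs from compound 3 in one place: chloro in place of pyrrolidin-1-yl on an aromatic carbon. Within the data shown here, no step between two measured compounds covers this change, so its size is uncertain; a move toward stronger inhibition, perhaps beyond the scatter, is expected in this assay, though compound 4 may still sit at the limit. Compound 4 is expected to give 40000 nM, with a range from 3000 nM to 100000 nM, which would be the expected step of an at least 2.5-fold lower number from compound 3 to compound 4 (0.39 log units; beyond the scatter).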

Compound 4, half-maximal inhibitory concentration: 39 nM
Estimate against measurement, compound 4: 1000-fold (3.01 log units) above; measured number below the stated range.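

In this assay, exchanging 2-(pyrrolidin-1-yl)pyridin-4-yl for 2-chloropyridin-4-yl gives an at least 2500-fold lower number from compound 3 to compound 4 (3.40 log units; beyond the scatter) and provides the first one-place comparison, showing that the group at this position alone can decide whether inhibition is seen on this core. Compound 3 is held at a limit of the assay, so the step has no upper bound: the limit of > 100000 nM in this assay, at which 2 of the 4 values shown sit. Going by these compounds, it remains open whether chloro itself matters or only the loss of pyrrolidin-1-yl, which hydrogen, methyl, methoxy or dimethylamino at this position could help separate.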